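Swapping One Methoxy for Hydrogen on Compound 3

The source may hold more compounds than are shown below. What is called first, only, known or untested is meant among the compounds shown, and "the series" means these compounds.

Among the measured compounds shown here, in a functional assay on A549 cells (Homo sapiens) for cytotoxicity, read by MTT assay, with a stated time of 6 days (on this read-out lower numbers stand for an effect already at smaller amounts and higher numbers for an effect only at larger amounts of compound), only three compounds have been measured so far. Compound 1 (`COC(=O)c1c(-c2cc(OC)cc(OC)c2)oc2ccccc2c1=O`) gives > 25 ug/mL, which is a limit of the assay and not a number. For the measured compounds named here, compound 2 (`COC(=O)c1c(-c2ccc(OCc3ccccc3)cc2)oc2ccc(OC)cc2c1=O`) gives 22.1 ug/mL, the only true number so far. Compound 3 (`COc1cc(-c2oc3ccccc3c(=O)c2C(=O)O)cc(OC)c1OC`) gives > 25 ug/mL, again a limit and not a number. Compound 3 therefore has no exact position, and its place is the limit of > 25 ug/mL in this assay, at which 2 of the 3 values shown sit.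

Compound 4 (`COc1cc(OC)cc(-c2oc3ccccc3c(=O)c2C(=O)O)c1`) has not been measured yet. It differs from compound 3 by one change, hydrogen in place of methoxy on an aromatic carbon. Going by the values given here, no measured pair shows what this swap does in this assay, so the expectation is cautious: no shift beyond the usual scatter, in either direction. The expected step that the limit leaves unreadable from compound 3 to compound 4 is accordingly small. For compound 4 the estimate is 30 ug/mL, with an expected range from 18 ug/mL to 50 ug/mL, and another limit instead of a number is quite likely.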

Compound 4, concentration for half-maximal effect: > 25 ug/mL
Compound 4 was reported as a limit; the forecaster's own chance of this, stated with the estimate: 75%; the middle value does not contradict the limit.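

Compound 4 gives a limit and not a number, as do compound 1 and compound 3, so neither the step from compound 3 nor the step from compound 1 to compound 4 can be read: the limit of > 25 ug/mL in this assay, at which 3 of the 4 values shown sit.

The compounds shown leave open whether either swap, hydrogen in place of methoxy or hydrogen in place of methyl, changes the result in this assay at all.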